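The source may hold more compounds than are shown below. What is called first, only, known or untested is meant among the compounds shown, and "the series" means these compounds.

Three compounds that share one core and differ in a single group on an aromatic carbon have been measured in a functional assay (mast cells) for inhibition, with Rattus norvegicus as the target; a lower number here means that less compound is needed, a higher number that more compound is needed for the effect. Compound 1 `CC1CC/C(=N\Nc2ccc(F)cc2)c2ncc(C(=O)O)c(=O)n21`, which carries fluoro, gives 1200 nM. Compound 2 `CCOc1ccc(N/N=C2\CCC(C)n3c2ncc(C(=O)O)c3=O)cc1`, which carries ethoxy, gives 17600 nM, and compound 3 `CC1CC/C(=N\Nc2ccc([N+](=O)[O-])cc2)c2ncc(C(=O)O)c(=O)n21`, which carries nitro, gives 8900 nM. Compound 3 therefore sits level with compound 2, with a 2.0-fold lower number from compound 2 to compound 3 (0.30 log units; within the scatter), and well apart from the fluoro compound, with a 7.4-fold higher number from compound 1 to compound 3 (0.87 log units; beyond the scatter).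

Compound 4 `CC(=O)c1ccc(N/N=C2\CCC(C)n3c2ncc(C(=O)O)c3=O)cc1` has not yet been measured. It has acetyl in place of nitro on an aromatic carbon, para to a large group: acetyl in place of nitro on an aromatic carbon. Among the measured compounds shown here, no measured step makes this exact swap, so the guide is the other swaps at this carbon. Leaving fluoro gave a 15-fold higher number from compound 1 to compound 2 (1.17 log units; beyond the scatter) and a 7.4-fold higher number from compound 1 to compound 3 (0.87 log units; beyond the scatter), yet the swap between the two replacements gave only a 2.0-fold lower number from compound 2 to compound 3 (0.30 log units; within the scatter). Among these three compounds, only fluoro stands apart, and acetyl is a further group that is not fluoro. In this assay, no step beyond the scatter is therefore expected, though a move towards compound 1 cannot be excluded. The expected change is a 1.3-fold lower number from compound 3 to compound 4 (0.10 log units; within the scatter). Compound 4 is estimated at 7000 nM, with an expected range from 2500 nM to 18000 nM.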

Compound 4, half-maximal effective concentration: 8100 nM
The estimate for compound 4 lay 1.2-fold (0.06 log units) below the measured number; measured number inside the range.
By their numbers in this assay, from the lowest: compound 1; then compounds 4, 3 and 2 (each within the scatter of the next, the first and the last beyond it).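

In this assay, acetyl and nitro on this aromatic carbon give numbers that cannot be told apart (a 1.1-fold lower number from compound 3 to compound 4 (0.04 log units; within the scatter)), even though acetyl has one hydrogen-bond acceptor where nitro has two and the two groups differ in their atoms. Fluoro now stands apart from a third group (a 6.8-fold higher number from compound 1 to compound 4 (0.83 log units; beyond the scatter)), so compound 1 has the lowest number of the four, and none of the compounds goes against that. The result also separates acetyl from ethoxy by a modest step just beyond the scatter (a 2.2-fold lower number from compound 2 to compound 4 (0.34 log units; beyond the scatter)), while compound 3 remains within the scatter of both, and no measurement shown here explains any of these steps.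

On these data alone, what stays open is whether the low number of compound 1 belongs to fluoro alone, or whether chloro or a plain hydrogen on this carbon would give a similar result. It is also open how an amine or a carboxylic acid at this place would compare, as the compounds shown carry neither group on this carbon.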